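A Thiazole Amide in Place of the Chlorofuran

The source may report more compounds than this note shows. Statements on the series, on what has been measured and on what is new or still open speak of the compounds shown alone.

In a functional assay for positive allosteric modulation of metabotropic glutamate receptor 1 (Homo sapiens), read by calcium flux, in the presence of a further agent that is not named here (a lower number here means that less compound is needed, a higher number that more compound is needed for the effect), compound 1 `Cc1cc(N2C(=O)C3=C(CCCC3)C2=O)c(F)cc1NC(=O)c1occc1C` gives 58 nM.
Compound 2 `Cc1cc(N2C(=O)C3=C(CCCC3)C2=O)c(F)cc1NC(=O)c1ccco1` gives only the assay's limit, > 10000 nM.
Compound 3 `Cc1cc(N2C(=O)C3=C(CCCC3)C2=O)c(F)cc1NC(=O)c1ccc(Cl)o1` likewise gives only a limit, > 10000 nM.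

Compound 3 thus stands at the limit of > 10000 nM in this assay, at which 2 of the 3 values shown sit, so its number is not known, only that it lies beyond the limit; the step of an at least 170-fold higher number from compound 1 to compound 3 (2.23 log units; beyond the scatter) shows that the ring on the carbonyl carbon can move the read-out strongly, while a step that the two limits leave unreadable from compound 2 to compound 3 cannot be read at all. Compound 4 `Cc1nc(C(=O)Nc2cc(F)c(N3C(=O)C4=C(CCCC4)C3=O)cc2C)cs1` differs from compound 3 in one place: 2-methyl-1,3-thiazol-4-yl in place of 5-chlorofuran-2-yl on a carbonyl carbon. Among the compounds with values here, no measured compound carries this ring, so the step to compound 4 rests on little more than the large step from compound 1 to compound 3. Compound 4 is expected to give 3000 nM, within 300 nM to 10000 nM, an estimated step of an at least 3.3-fold lower number from compound 3 to compound 4 (0.52 log units; beyond the scatter).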

Compound 4, half-maximal effective concentration: > 10000 nM
Compound 4: only a limit was reported; the forecaster's own chance of this, stated with the estimate: 45%; middle value at least 3.3-fold (0.52 log units) from the limit.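

Compound 4 gives only a limit in this assay, so its steps to compound 2 and compound 3 cannot be read. Its step from the 3-methylfuran-2-yl amide can be read: an at least 170-fold higher number from compound 1 to compound 4 (2.23 log units; beyond the scatter). A ring with two hetero atoms and its own methyl, 2-methyl-1,3-thiazol-4-yl, therefore joins the two other rings at the limit, leaving 3-methylfuran-2-yl as the only ring on this carbonyl carbon with a measured number: the limit of > 10000 nM in this assay, at which 3 of the 4 values shown sit.

From the compounds shown here alone, how far compound 2, compound 3 and compound 4 lie beyond that limit stays open. So does whether a 3-ethylfuran-2-yl or 3-methylthiophen-2-yl ring here would give a measured number.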